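Tolerance notes on the series: compound 2 to compound 3

The compounds below may be only part of what the source reports. "The series", "measured", "known", "first", "only" and "open" are said of these compounds alone.

Compound 2 `COc1ccc(OCCCCCOc2cccc(NC(N)=S)c2)cc1` has been measured only in an ADME assay on Ava5 cells (Homo sapiens) for cytotoxicity; a higher number here means that more compound is tolerated, a lower number that less compound is tolerated. There compound 2 gives > 50000 nM, a limit rather than a number. Compound 1 `NC(=S)Nc1cccc(OCCCCCOc2ccccc2)c1` differs from compound 2 by methoxy in place of hydrogen on an aromatic carbon. In this assay compound 1 gives > 50000 nM, again a limit. The step that the two limits leave unreadable from compound 1 to compound 2 can therefore not be read in size. Both values sit at the limit of > 50000 nM in this assay, at which 2 of the 2 values shown sit. Compound 3 `NC(=S)Nc1cccc(OCCCCCOc2ccc(C(=O)O)cc2)c1` is not yet measured; it differs from compound 2 by carboxy in place of methoxy on an aromatic carbon. The only measured step in this assay is unreadable, so it bears on compound 3 only weakly, and no step in this series has shown a change beyond the scatter. The step that the limit leaves unreadable from compound 2 to compound 3 is therefore expected to be none beyond the scatter. For compound 3 the estimate in this assay is 70000 nM, between 30000 nM and 200000 nM, most likely reported again as a limit.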

Compound 3, half-maximal cytotoxic concentration: > 50000 nM
Compound 3 was reported as a limit; the forecaster's own chance of this, stated with the estimate: 85%; the middle value lies beyond the limit too.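

The steps from compound 2 to compound 3 and from compound 1 to compound 3 cannot be read in size in this assay: the limit of > 50000 nM in this assay, at which 3 of the 3 values shown sit.

The compounds shown leave open whether compound 1, compound 2 and compound 3 differ at all in tolerance in this assay, and whether methoxy or carboxy in place of hydrogen changes it.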